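Replacing Isopropyl with Aryl Groups: Binding Stays Flat

The source may hold more compounds than are shown below. What is called first, only, known or untested is meant among the compounds shown, and "the series" means these compounds.

Compound 1 `CC(C)N1CCN(Cc2csc(N)c2C(=O)c2ccc(Cl)cc2)CC1` gives 0% in an assay on CHO cells for displacement of a labelled ligand from adenosine receptor A1 (Homo sapiens), read by scintillation counting, with a stated time of 120 min, tested at 10 uM; on this read-out lower numbers stand for less inhibition and higher numbers for more inhibition at the one concentration tested (going by the name of the read-out).
Compound 2 `COc1ccc(N2CCN(Cc3csc(N)c3C(=O)c3ccc(Cl)cc3)CC2)cc1` gives 0% in this assay.
Compound 3 `Nc1scc(CN2CCN(c3cccc(C(F)(F)F)c3)CC2)c1C(=O)c1ccc(Cl)cc1` gives 0% in this assay.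

All three measured compounds share one core and differ only in the group on an amine nitrogen in a ring. Compound 1 stands level with compounds 2 and 3, and no value among the three is separated from another beyond the scatter. The two steps away from compound 1 are no change at the digits printed from compound 1 to compound 2 (within the scatter) and no change at the digits printed from compound 1 to compound 3 (within the scatter), and the step between the two aryl compounds is no change at the digits printed from compound 2 to compound 3 (within the scatter). Nothing here moves.

Compound 4 `Nc1scc(CN2CCN(c3ccc(OC(F)(F)F)cc3)CC2)c1C(=O)c1ccc(Cl)cc1` has not yet been measured. It differs from compound 1 as follows: 4-(trifluoromethoxy)phenyl in place of isopropyl on an amine nitrogen in a ring. Both earlier steps placed an aryl group on the same nitrogen and gave no change, so the step from compound 1 to compound 4 in this assay is expected to be no change at the digits printed from compound 1 to compound 4 (within the scatter). Compound 4 is therefore estimated at 0%, with a range from -10% to 12%.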

Compound 4, a percentage reported as inhibition, at one concentration (the size of the read-out at that concentration, not a potency): 0%
Compound 4: the middle estimate sits on the measured number at the digits printed; the range from low to high includes it.
By their numbers in this assay, from the lowest: compounds 1, 2, 3 and 4 (each within the scatter of the next).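

On this nitrogen, 4-(trifluoromethoxy)phenyl brings 11 heavy atoms and a hydrogen-bond acceptor where isopropyl has 3 heavy atoms and no acceptor, yet the reading in this assay holds (no change at the digits printed from compound 1 to compound 4 (within the scatter)). The reading also holds on moving from another fluorinated aryl group, 3-(trifluoromethyl)phenyl (no change at the digits printed from compound 3 to compound 4 (within the scatter)), and on placing trifluoromethyl instead of methyl on the oxygen of the aromatic ring (no change at the digits printed from compound 2 to compound 4 (within the scatter)). The data offer no evidence that explains this flat result.

Because all four readings are level, they cannot show whether any group at this nitrogen can produce inhibition. As far as these compounds go, whether a carboxylic acid or a longer alkyl chain there would give a reading different from that of compound 1 stays open.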